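Ring in place of a chain on the aromatic nitrogen

The source may hold more compounds than are shown below. What is called first, only, known or untested is meant among the compounds shown, and "the series" means these compounds.

The account concerns two measured compounds and one awaiting measurement in a functional assay on the whole organism with Mus musculus as the target; a higher number here means a larger maximal response, a lower number a smaller maximal response. Compound 1 `CCn1c(=O)n(C2OC(CO)[C@@H](O)[C@H]2O)c2nc(N)nc(O)c21` gives 82% in this assay. Compound 2 `C=CCn1c(=O)n(CCCCO)c2nc(N)nc(O)c21` gives 16%, the lower of the two numbers; the gap between compound 2 and compound 1 lies beyond the scatter, so compound 2 stands clearly below compound 1.

Compound 3 `C=CCn1c(=O)n(C2C=CC(CO)O2)c2nc(N)nc(O)c21` is not yet measured. It differs from compound 2 in one place: a group of 7 heavy atoms (5 carbon, 2 oxygen; one five-membered non-aromatic ring with 1 hetero atom) in place of a group of 5 heavy atoms (4 carbon, 1 oxygen; no ring), on an aromatic nitrogen. For the measured compounds named here, no step between measured compounds is recorded for this exchange, so only the two values above can guide an expectation.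

Compound 1 carries a ring on the same aromatic nitrogen and gives 82%, while the open chain of compound 2 goes with 16%. On that basis an upward step is expected, of a size well beyond the scatter, though with wide uncertainty since compound 1 and compound 3 also differ in their other groups. For compound 3 the expected step is a number 39 percentage points higher from compound 2 to compound 3 (beyond the scatter). Compound 3 is thus estimated at 55%, with a range from 25% to 85%.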

Compound 3, largest response reached (reported as maximal response), in percent of the reference or control that the assay uses: 84%
Estimate against measurement, compound 3: 29 percentage points below; low and high end bracket the measured number.
By their numbers in this assay, from the lowest: compound 2; then compounds 1 and 3 (each within the scatter of the next).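

In this assay, putting the five-membered non-aromatic ring with 1 hetero atom in place of the 4-hydroxybutyl group on the aromatic nitrogen gives a number 68 percentage points higher from compound 2 to compound 3 (beyond the scatter), so the response at this position depends strongly on the group it carries. For the compounds shown here, this is the first reading of the exchange with the allyl group held constant, which the earlier compounds could not give, since compound 1 and compound 2 differ in more than one place. No measurement shown accounts for the step, so it cannot be assigned to the ring itself or to its double bond outside aromatic rings.

The compounds shown leave open whether an amine or a carboxylic acid at the end of the 4-hydroxybutyl group, or a longer chain on the same nitrogen, would move the response, since a single open chain stands against the ring here. As far as these compounds go, it also remains open whether the same exchange would give a step of this size with a propyl group in place of the allyl group.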